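Hydrogen for methyl on the aryl ring: cytotoxicity outlook

The compounds below may be only part of what the source reports. "The series", "measured", "known", "first", "only" and "open" are said of these compounds alone.

Compound 1 `Cc1ccc(-c2nn(-c3ccc(F)cc3F)cc2CNCCN2CCN(C)CC2)cc1` is the reference point in an ADME assay on Huh-7 cells (Homo sapiens) for cytotoxicity; a higher number here means that more compound is tolerated, a lower number that less compound is tolerated. For compound 1 the outcome is a limit of the assay rather than a number, > 20000 nM, which stands at the limit of > 20000 nM in this assay, at which 1 of the 2 values shown sits. Compound 2 `CN1CCN(CCNCc2cn(-c3ccc(C(F)(F)F)cc3)nc2-c2ccc(Cl)cc2)CC1` in this assay gives 3000 nM; no step between compound 1 and compound 2 is counted, the two values stand as shown. Compound 3 `CN1CCN(CCNCc2cn(-c3ccc(F)cc3F)nc2-c2ccccc2)CC1` differs from compound 1 by hydrogen in place of methyl on an aromatic carbon. In this assay a step no larger than the scatter, in either direction, is expected from compound 1 to compound 3. Compound 3 is therefore expected near 20000 nM, within 7000 nM to 50000 nM. The step expected is a number no higher from compound 1 to compound 3 (the limit leaves the size open).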

Compound 3, half-maximal cytotoxic concentration: > 20000 nM
Compound 3: a limit, no number; the forecaster's own chance of this, stated with the estimate: 60%; the middle value sits exactly at the limit.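

Among the compounds shown here, compound 3 gives > 20000 nM in this assay, a limit and not a number; compound 1 also stands at a limit, so no step between compound 1 and compound 3 can be read. The compounds shown leave open whether 4-methylphenyl to phenyl shifts the tolerated concentration at all.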